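Amide in Place of Acid: Cytotoxicity Expected Unchanged

The source may report more compounds than this note shows. Statements on the series, on what has been measured and on what is new or still open speak of the compounds shown alone.

Compound 2 `COc1ccc(C(=O)/C=C/c2ccc(C(=O)O)cc2)c(O)c1` carries a carboxylic acid on the shared core. In an ADME assay on SH-SY5Y cells (Homo sapiens) for cytotoxicity, read by MTT assay, with a stated time of 48 h (a higher number here means a weaker inhibitor, a lower number a stronger inhibitor), compound 2 gives only a limit of the assay, > 100000 nM, and no number. Going by the values given here, compound 1 `COc1ccc(C(=O)/C=C/c2ccc(C(=O)Nc3cc([N+](=O)[O-])ccc3O)cc2)c(O)c1` is the one other compound with a value here. In this assay compound 1 likewise gives a limit, > 100000 nM. Compound 2 therefore stands where every value shown stands, at the limit of > 100000 nM in this assay, at which 2 of the 2 values shown sit. Compound 3 `COc1ccc(C(=O)/C=C/c2ccc(C(=O)Nc3ccccc3O)cc2)c(O)c1` has not yet been measured in this assay. It differs from compound 2 in one place: (2-hydroxyphenyl)amino in place of hydroxy on a carbonyl carbon. Among the compounds with values here, no step between measured compounds is available as precedent. He expects no step beyond the scatter, a number no higher from compound 2 to compound 3 (the limit leaves the size open), given that both measured values sit at the limit of > 100000 nM in this assay, at which 2 of the 2 values shown sit. He estimates compound 3 in this assay at 100000 nM, within 30000 nM to 300000 nM, and most likely reported again only as a limit.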

Compound 3, half-maximal inhibitory concentration: > 100000 nM
Compound 3: only a limit was reported; the forecaster's own chance of this, stated with the estimate: 80%; the middle value sits exactly at the limit.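

In this assay compound 3 gives only a limit, > 100000 nM. No step can be read from compound 2 to compound 3 or from compound 1 to compound 3: the limit of > 100000 nM in this assay, at which 3 of the 3 values shown sit. The compounds shown leave open how far any of them lies beyond that limit in this assay, and so whether the changes among them make any difference there.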